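The source may report more compounds than this note shows. Statements on the series, on what has been measured and on what is new or still open speak of the compounds shown alone.

Of the compounds shown here, two built on a shared core have so far been tested in a functional assay on U-87MG ATCC cells for antiproliferative activity against U-87 MG (Homo sapiens), read by MTT assay, with a stated time of 72 h; on this read-out higher numbers stand for weaker inhibition and lower numbers for stronger inhibition. Compound 1, `CNC(=O)c1cc(Oc2ccc(NC(=O)c3cc4cccnc4n(-c4ccc(F)cc4)c3=O)cc2)ccn1`, gives 2910 nM in this assay. Compound 2, `CCCNC(=O)c1cc(Oc2ccc(NC(=O)c3cc4cccnc4n(-c4ccccc4)c3=O)cc2)ccn1`, gives 1510 nM in this assay. Compound 2 stands at the low end of these two numbers, but its nearest neighbour is compound 1, and the gap between them lies within the usual scatter, so the two cannot be told apart on this assay. Compound 1 and compound 2 also differ in more than one place, so no single change can be read out of their pair.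

Compound 3, `CCCNC(=O)c1cc(Oc2ccc(NC(=O)c3cc4cccnc4n(-c4ccc(F)cc4)c3=O)cc2)ccn1`, has not yet been measured. It differs from compound 2 in one place only: fluoro in place of hydrogen on an aromatic carbon, in words, fluoro in place of hydrogen on an aromatic carbon. Going by the values given here, no measured pair isolates this change, so there is no step on record to lean on. The step from compound 2 to compound 3 in this assay is expected to be small, a 1.2-fold higher number from compound 2 to compound 3 (0.08 log units; within the scatter), in neither direction beyond the scatter. Compound 3 is therefore estimated at 1800 nM, within a range from 700 nM to 4500 nM.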

Compound 3, half-maximal inhibitory concentration: 960 nM
Beside the measured number, compound 3's estimate is 1.9-fold (0.27 log units) above it, within the range that was stated.
By their numbers in this assay, from the lowest: compounds 3, 2 and 1 (each within the scatter of the next, the first and the last beyond it).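

In this assay, the phenyl to 4-fluorophenyl change gives a 1.6-fold lower number from compound 2 to compound 3 (0.20 log units; within the scatter) and so cannot be told apart from repeat-measurement noise; on this aromatic carbon, para to a large group, fluoro in place of hydrogen therefore has no readable effect on the number. Compound 1 and compound 3 share the 4-fluorophenyl group and differ only by ethyl in place of hydrogen on a saturated chain carbon bound to an amide-type nitrogen, and this pair gives a 3.0-fold lower number from compound 1 to compound 3 (0.48 log units; beyond the scatter) as a modest step, the only one on record that clears the scatter, so in this series the chain on the amide is the place where a change can be read. Nothing on record explains why either step has the size it has.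

Only hydrogen and fluoro are shown on this ring carbon, so whether a chloro or a methoxy group there would shift the number beyond the scatter stays open. Only methyl and propyl are shown on the amide nitrogen, and these two cannot tell whether a longer chain such as butyl, or a chain carrying an amine, would go further in the same direction.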